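Chloro to methoxy in a tolerated series

The compounds below may be only part of what the source reports. "The series", "measured", "known", "first", "only" and "open" are said of these compounds alone.

Measured in an ADME assay on HEK293 cells (Homo sapiens) for cytotoxicity, read by resazurin assay, with a stated time of 72 h; a lower number here means that less compound is tolerated, a higher number that more compound is tolerated:
- compound 1 `CCc1cccc(CNC(=O)c2nc3cccc(COc4ccc(CC(=O)O)cc4)c3c(=O)[nH]2)c1`: > 20000 nM (a limit)
- compound 2 `CCc1cccc(CNC(=O)c2nc3cccc(COCc4ccc(C(=O)O)cc4)c3c(=O)[nH]2)c1`: > 40000 nM (a limit)
- compound 3 `CCc1cccc(CNC(=O)c2nc3ccc(Cl)c(COCc4ccc(C(=O)O)cc4)c3c(=O)[nH]2)c1`: > 20000 nM (a limit)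

All three values are limits, not numbers. Compound 3 stands only at a limit, > 20000 nM. That is the limit of > 20000 nM in this assay, at which 2 of the 3 values shown sit; the other is the limit of > 40000 nM in this assay, at which 1 of the 3 values shown sits.

Compound 4 `CCc1cccc(CNC(=O)c2nc3ccc(OC)c(COCc4ccc(C(=O)O)cc4)c3c(=O)[nH]2)c1` differs from compound 3 by methoxy in place of chloro on an aromatic carbon. Among the measured compounds shown here, two measured steps bear on this: a step that the two limits leave unreadable from compound 2 to compound 3, which concerns the same aromatic carbon, and a step that the two limits leave unreadable from compound 1 to compound 2. Neither has a readable size, so neither gives a measured size to carry over.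

In this assay no step beyond the scatter is expected: a step that the limit leaves unreadable from compound 3 to compound 4. The estimated value for compound 4 is 30000 nM, with an expected range of 15000 nM to 60000 nM.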

Compound 4, half-maximal cytotoxic concentration: > 20000 nM
Compound 4: a limit, no number (the forecaster's own chance of this, stated with the estimate: 85%); the middle value is on the limit's open side.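

In this assay the values of compound 2, compound 3 and compound 4 are all limits, and no step can be read among them. The compounds shown leave open whether methoxy and chloro differ at all in tolerated concentration.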